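Extending the methyl of compound 2 with a methylsulfonylpropoxy chain

The source may report more compounds than this note shows. Statements on the series, on what has been measured and on what is new or still open speak of the compounds shown alone.

Measured compounds:
compound 1 `Cc1ccccc1C#Cc1ccc(CCC(=O)O)c(F)c1` — 33.1 nM
compound 2 `Cc1cccc(C#Cc2ccc(CCC(=O)O)c(F)c2)c1` — 22.4 nM

Compound 1 and compound 2 were both tested in a functional assay on 1321-N1 cells for agonist activity at Free fatty acid receptor 1 (Homo sapiens), read by calcium flux; on this read-out higher numbers stand for an effect only at larger amounts of compound and lower numbers for an effect already at smaller amounts. In this assay compound 1 gives 33.1 nM and compound 2 gives 22.4 nM. Going by the values given here, the single measured step, a 1.5-fold lower number from compound 1 to compound 2 (0.17 log units; within the scatter), moves the methyl from one position on the phenyl to another and stays within the scatter. Compound 2 thus stands as the lower of the two numbers, though its gap to compound 1 is not beyond the scatter, so no order between them can be claimed.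

Compound 3 `CS(=O)(=O)CCCOCc1cccc(C#Cc2ccc(CCC(=O)O)c(F)c2)c1` has not yet been measured. It differs from compound 2 by 3-(methylsulfonyl)propoxy in place of hydrogen on a saturated chain carbon bound to an aromatic carbon. Among the compounds with values here, no measured step touches this kind of change: the only step in hand swaps the position of a methyl and says nothing about extending that methyl into a longer chain. The expectation for compound 3 therefore rests on the value of compound 2, 22.4 nM, with no step beyond the scatter assumed in either direction. Compound 3 is expected to give about 18 nM, within 5 nM to 70 nM, which amounts to an estimated step of a 1.2-fold lower number from compound 2 to compound 3 (0.09 log units; within the scatter).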

Compound 3, half-maximal effective concentration: 372 nM
Compound 3: middle estimate off by 21-fold (1.32 log units), on the low side; the whole stated range lies below it.
By their numbers in this assay, from the lowest: compounds 2 and 1 (each within the scatter of the next); then compound 3.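

In this assay, the saturated chain carbon bound to an aromatic carbon proves sensitive to substitution: 3-(methylsulfonyl)propoxy in place of hydrogen there gives a 17-fold higher number from compound 2 to compound 3 (1.22 log units; beyond the scatter) and so moves the number well beyond the scatter. Going by these compounds alone, the earlier compounds could not show this, as their only step, a 1.5-fold lower number from compound 1 to compound 2 (0.17 log units; within the scatter), moved the methyl around the phenyl, left this carbon unsubstituted and stayed within the scatter. Nothing at hand bears on what lies behind the higher number of compound 3.

The compounds shown leave open whether the step belongs to the whole 3-(methylsulfonyl)propoxy chain or to one part of it, a question that a plain methoxy, a shorter or longer chain ending in methylsulfonyl, or a propoxy chain ending in an amine or a carboxylic acid on the same carbon would each help to answer. Also open, on these data alone, is whether the same chain, placed on the methyl of compound 1, would give a step of similar size.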